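Benzylamide Ester Swap on a Free-Amine Analogue

A few compounds are considered here, and "the series" means these few. Any claim that something is new, unique, unknown or untested is made for them only; others in the source may bear on it.

Measured so far:
compound 1 `CC(C)(C)OC(=O)NCCCCCN1C(Nc2ccc(-c3ccccc3)cc2)=Nc2ccccc2C1CC(=O)NCc1ccccc1` — 30.1%
compound 2 `COC(=O)CC1c2ccccc2N=C(Nc2ccc(-c3ccccc3)cc2)N1CCCCCN` — 7.5%

In an assay on HEK293 cells for inhibition of Voltage-dependent N-type calcium channel subunit alpha-1B (Homo sapiens), tested at 10 uM (on this read-out higher numbers stand for more inhibition at the one concentration tested (going by the name of the read-out) and lower numbers for less inhibition), compound 2 gives the lowest of the two numbers shown; compound 1 stands higher by a gap beyond the scatter, though these two differ in more than one place, so only their two values can be compared. Compound 3 `NCCCCCN1C(Nc2ccc(-c3ccccc3)cc2)=Nc2ccccc2C1CC(=O)NCc1ccccc1` keeps the free amine chain of compound 2 and carries the change (benzylamino in place of methoxy on a carbonyl carbon). Compound 1 already bears the benzylcarbamoyl group, which is read as a hint that the step should go upward. An upward step is expected, estimated as a number 10.5 percentage points higher from compound 2 to compound 3 (beyond the scatter), of modest size and possibly not beyond the scatter. For compound 3 the expected inhibition is 18%, within 5% to 35%.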

Compound 3, a percentage reported as inhibition, at one concentration (the size of the read-out at that concentration, not a potency): 15.2%
Compound 3: middle estimate off by 2.8 percentage points, on the high side; measured number inside the range.
By their numbers in this assay, from the lowest: compounds 2 and 3 (each within the scatter of the next); then compound 1.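

In this assay, benzylamino in place of methoxy on a carbonyl carbon gives a number 7.7 percentage points higher from compound 2 to compound 3 (within the scatter), so with the free amine chain this change does not stand clear of the scatter. Among the compounds shown here, with the benzylcarbamoyl group held constant, hydrogen in place of tert-butoxycarbonyl on an amine nitrogen gives a number 14.9 percentage points lower from compound 1 to compound 3 (beyond the scatter), which places the one step beyond the scatter at that nitrogen rather than at the carbonyl carbon. No available evidence bears on either step. Open, on these data alone, is how a carboxylic acid or a primary amide on that carbonyl carbon would read. Also open, as far as these compounds go, is whether the benzylamino step holds with tert-butoxycarbonyl on the amine nitrogen.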